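Dimethylamino to pyrrolidin-1-yl on the shared core

The compounds below may be only part of what the source reports. "The series", "measured", "known", "first", "only" and "open" are said of these compounds alone.

Among the measured compounds shown here, in a functional assay on CCRF-CEM cells (Homo sapiens) for antiproliferative activity, read by cell counting, with a stated time of 2 days (on this read-out lower numbers stand for stronger inhibition and higher numbers for weaker inhibition), compound 1 (`COc1cc(C(=O)c2sc(N(C)C)nc2N)cc(OC)c1OC`) gives 11000 nM as the only true number so far. Compound 2 (`COc1cc(C(=O)c2sc(N(C)Cc3ccccc3)nc2N)cc(OC)c1OC`) reads > 200000 nM and that is a limit, not a number. Compound 3 (`COc1cc(C(=O)c2sc(N3CCCC3)nc2N)cc(OC)c1OC`) carries pyrrolidin-1-yl in place of dimethylamino on an aromatic carbon of the shared core. For the measured compounds named here, the one measured step of an at least 18-fold higher number from compound 1 to compound 2 (1.25 log units; beyond the scatter) is large, but it brings in phenyl, which compound 3 lacks, so it bears only loosely. As far as these compounds go, no step beyond the scatter is therefore expected in this assay, and the direction stays open. The expected step of a 1.1-fold lower number from compound 1 to compound 3 (0.04 log units; within the scatter) is an estimate only. For compound 3 the estimated value is 10000 nM with an expected range from 3000 nM to 35000 nM in this read-out.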

Compound 3, half-maximal inhibitory concentration: 320 nM
Beside the measured number, compound 3's estimate is 31-fold (1.49 log units) above it; measured number outside the range, below it.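

In this assay, pyrrolidin-1-yl in place of dimethylamino gives a 34-fold lower number from compound 1 to compound 3 (1.54 log units; beyond the scatter). This aromatic carbon of the shared core therefore responds strongly to the choice of amine, not only to the addition of phenyl, and pyrrolidin-1-yl in place of benzyl(methyl)amino gives an at least 620-fold lower number from compound 2 to compound 3 (2.79 log units; beyond the scatter). Compound 2 stands at a limit of the assay, not a number: the limit of > 200000 nM in this assay, at which 1 of the 3 values shown sits.

The compounds shown leave open whether the ring itself matters, which diethylamino at this carbon would test. They also leave open how ring size and a further ring hetero atom bear on the result, as azetidin-1-yl, piperidin-1-yl or morpholin-4-yl would show.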